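A few compounds are considered here, and "the series" means these few. Any claim that something is new, unique, unknown or untested is made for them only; others in the source may bear on it.

Compound 1 `COc1ccc(C(=O)Nc2ccccc2C(F)(F)F)cc1OC1CCCC1`: 3100 nM
Compound 2 `COc1ccc(C(=O)Nc2ccccc2O)cc1OC1CCCC1`: 1300 nM

In an assay on isolated protein for inhibition of phosphodiesterase 4A (Sus scrofa) (a lower number here means a stronger inhibitor, a higher number a weaker inhibitor), compound 2 gives the lower of the two numbers, and the step of a 2.4-fold lower number from compound 1 to compound 2 (0.38 log units; beyond the scatter) lies beyond the scatter. Compound 3 `COc1ccc(C(=O)Nc2c(C)nsc2Br)cc1OC1CCCC1` differs from compound 2 by 5-bromo-3-methyl-1,2-thiazol-4-yl in place of 2-hydroxyphenyl on an amide-type nitrogen. For the measured compounds named here, no measured step covers an exchange of the whole ring on the amide-type nitrogen; the only known step concerns a group on the ring that now leaves, and the hydroxy that went with the lower number is lost. A modest weakening is expected: a 1.9-fold higher number from compound 2 to compound 3 (0.28 log units; within the scatter). Compound 3 is therefore estimated at 2500 nM, within 800 nM to 8000 nM.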

Compound 3, half-maximal inhibitory concentration: 500 nM
Compound 3: middle estimate off by 5.0-fold (0.70 log units), on the high side, outside the stated range (below it).
By their numbers in this assay, from the lowest: compound 3; then compound 2; then compound 1.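

The ring on the amide-type nitrogen can be exchanged as a whole: in this assay this change gives a 2.6-fold lower number from compound 2 to compound 3 (0.41 log units; beyond the scatter). The hydroxy of compound 2 is therefore not needed for a lower number, since compound 3 lacks it. Nothing available here bears on the reason for this step.

Bromine, methyl and the ring itself all change together in compound 3, so their separate shares remain unknown. As far as these compounds go, it also remains open how chlorine in place of bromine, or an amine in place of methyl, would affect the number.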